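The source may hold more compounds than are shown below. What is called first, only, known or untested is meant among the compounds shown, and "the series" means these compounds.

Compound 1 `CC1=CC[C@@H]([C@@](C)(O)CCCC(C)(C)NC=S)CC1` gives 11400 nM in a functional assay on HT-29 cells (Homo sapiens) for cytotoxicity, read by sulforhodamine B assay; on this read-out lower numbers stand for stronger inhibition of growth and higher numbers for weaker inhibition of growth. Compound 2 `CC1=CC[C@@H]([C@@](C)(O)CCCC(C)(C)NC(=S)NN)CC1` gives 49400 nM in this assay.

Compound 2 thus stands at the higher of the two numbers, the weaker growth inhibitor, and the step of a 4.3-fold higher number from compound 1 to compound 2 (0.64 log units; beyond the scatter) lies beyond the scatter. Compound 3 `CC1=CC[C@@H]([C@@](C)(O)CCCC(C)(C)NC(=S)N/N=C\c2ccccc2)CC1` is the next compound and it differs from compound 2 in one place: a group of 8 heavy atoms (7 carbon, 1 nitrogen; one six-membered aromatic ring of carbon only) in place of one nitrogen atom, on an amide-type nitrogen. Within the data shown here, the one measured step that touches the same end of the molecule, a 4.3-fold higher number from compound 1 to compound 2 (0.64 log units; beyond the scatter), was modest and went toward weaker inhibition; it added the amino group that now leaves again. Among the measured compounds shown here, since only that step is known, the expected move in this assay is modest and its direction uncertain, leaning toward a lower number than compound 2 shows. Compound 3 is therefore expected at about 20000 nM, between 4000 nM and 100000 nM. That estimate would mean a step of a 2.5-fold lower number from compound 2 to compound 3 (0.39 log units; beyond the scatter).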

Compound 3, concentration for 50% growth inhibition: 9960 nM
Beside the measured number, compound 3's estimate is 2.0-fold (0.30 log units) above it, and the stated range covers the measured number.
By their numbers in this assay, from the lowest: compounds 3 and 1 (each within the scatter of the next); then compound 2.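

In this assay, the place on the amide-type nitrogen takes a far larger group than amino, and the group with the six-membered aromatic ring gives a 5.0-fold lower number from compound 2 to compound 3 (0.70 log units; beyond the scatter). Adding atoms at this end of the molecule therefore does not always go toward weaker inhibition, as the single earlier step might have suggested, and the longer end group leaves the number level with that of the plain thiocarbonyl compound, with a 1.1-fold lower number from compound 1 to compound 3 (0.06 log units; within the scatter). No measurement at hand explains why the amino group and the larger group differ in this way.

Going by these compounds, it remains open whether the aromatic ring or the double bond outside it matters more for this recovery. On these data alone, how a pyridine ring, or a chlorine atom on the aromatic ring, would behave at this place also remains unknown.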